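The source may hold more compounds than are shown below. What is called first, only, known or untested is meant among the compounds shown, and "the series" means these compounds.

Measured compounds:
compound 1, `O=C(O)Cc1sc(C(c2ccc(F)cc2)c2ccc(F)cc2)nc1-c1cc(F)cc(F)c1`, 35 nM
compound 2, `O=C(O)Cc1sc(C(c2ccc(F)cc2)c2ccc(F)cc2)nc1-c1cccc(F)c1`, 1.4 nM

Compound 2 holds the lowest of the two numbers in an in vitro assay on HEK385-7 cells for displacement of a labelled ligand from prostaglandin D2 receptor 2 (Homo sapiens); on this read-out lower numbers stand for stronger inhibition and higher numbers for weaker inhibition; the other stands apart by a 25-fold lower number from compound 1 to compound 2 (1.40 log units; beyond the scatter). Compound 3, `Cc1cc(-c2nc(C(c3ccc(F)cc3)c3ccc(F)cc3)sc2CC(=O)O)cnc1N`, is not yet measured and carries 6-amino-5-methylpyridin-3-yl in place of 3-fluorophenyl on an aromatic carbon. For the measured compounds named here, the single measured step, a 25-fold lower number from compound 1 to compound 2 (1.40 log units; beyond the scatter), alters the same group but only by a fluoro, and nothing measured speaks to a ring exchange of this kind, so no direction can be read from the data. The number for compound 3 is therefore expected close to that of compound 2, a step of a 2.1-fold higher number from compound 2 to compound 3 (0.33 log units; beyond the scatter), with wide uncertainty. Compound 3 is estimated at 3 nM, range 0.7 nM to 15 nM.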

Compound 3, half-maximal inhibitory concentration: 880 nM
For compound 3 the middle estimate is 290-fold (2.47 log units) below the measured one; measured number outside the range, above it.
By their numbers in this assay, from the lowest: compound 2; then compound 1; then compound 3.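

In this assay this position, next to the ring nitrogen, proves highly sensitive to exchange of the whole aryl group: 6-amino-5-methylpyridin-3-yl in place of 3-fluorophenyl gives a 630-fold higher number from compound 2 to compound 3 (2.80 log units; beyond the scatter). The same group in place of 3,5-difluorophenyl gives a 25-fold higher number from compound 1 to compound 3 (1.40 log units; beyond the scatter), so the fluorinated phenyl rings both keep lower numbers than this aminopyridine. No available evidence accounts for the loss.

Going by these compounds, the exchange changes the ring nitrogen, amine and methyl together, so the share of each remains open. A plain pyridin-3-yl or a 6-aminopyridin-3-yl would help separate them.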